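Swapping the aryl ring on a thioether-linked enone

The compounds below may be only part of what the source reports. "The series", "measured", "known", "first", "only" and "open" are said of these compounds alone.

Measured compounds and their values:
- Compound 1, `Cc1ccc(CS/C(=C/c2ccc(F)c(C)c2)C(=O)c2ccc(Cl)cc2)cc1`: 25000 nM
- Compound 2, `COc1ccc(S(=O)(=O)/C(=C/c2ccc(C)s2)C(=O)c2ccc(Cl)cc2)cc1`: 25000 nM
- Compound 3, `COc1ccccc1/C=C(\C(=O)c1ccc(Cl)cc1)S(=O)(=O)c1ccc(Br)cc1`: 10000 nM

All three were tested in a functional assay on DU-145 cells (Homo sapiens) for inhibition, read by trypan blue exclusion, with a stated time of 96 h; on this read-out higher numbers stand for weaker inhibition of growth and lower numbers for stronger inhibition of growth. Compound 1 and compound 2 sit level at the digits shown, and together they carry the highest numbers of the three. Compound 3 gives the lowest number; its gap to compound 1 lies beyond the usual scatter of the measurement. Among the compounds with values here, only these three numbers are known, and none of the measured pairs differs in a single place, so no step between measured compounds can be read off directly.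

Compound 4, `Cc1ccc(CS/C(=C/c2ccc(C)s2)C(=O)c2ccc(Cl)cc2)cc1`, has not yet been measured. It differs from compound 1 in one place: 5-methylthiophen-2-yl in place of 4-fluoro-3-methylphenyl on a double-bonded chain carbon bound to a double-bonded chain carbon. Compound 2 already carries the 5-methylthiophen-2-yl group, though on a different core, and in this assay compound 2 gives the same number as compound 1. Within the data shown here, there is no measured step that tells what this exchange alone does, so no direction is assumed.

Compound 4 is expected to stay close to compound 1, with the step from compound 1 to compound 4 estimated as no change at the digits printed from compound 1 to compound 4 (within the scatter), that is, no change beyond the scatter. The estimate for compound 4 is 25000 nM, within a range of 10000 nM to 60000 nM.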

Compound 4, concentration for 50% growth inhibition: 50000 nM
Estimate against measurement, compound 4: 2.0-fold (0.30 log units) below; the measured number falls inside the stated range.
By their numbers in this assay, from the lowest: compound 3; then compounds 1, 2 and 4 (each within the scatter of the next).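

In this assay, within the data shown here, placing 5-methylthiophen-2-yl in place of 4-fluoro-3-methylphenyl on a double-bonded chain carbon bound to a double-bonded chain carbon gives a 2.0-fold higher number from compound 1 to compound 4 (0.30 log units; within the scatter), and this is the first direct reading of a single change at this position. On the core of compound 1, a five-membered aromatic ring with 1 hetero atom can therefore stand in for a six-membered aromatic ring of carbon only with no difference that clears the scatter, though this rests on one pair alone. Nothing measured here accounts for this outcome or links it to any property of either ring.

From the compounds shown here alone, whether the same exchange would give a similar result on the different core of compound 2 and compound 3 remains open. Also unknown is how this position would respond to a group of a different kind, such as an amine, a carboxylic acid or a longer alkyl chain in place of the aromatic ring.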